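A few compounds are considered here, and "the series" means these few. Any claim that something is new, unique, unknown or untested is made for them only; others in the source may bear on it.

Measured in a functional assay on COLO 205 cells (Homo sapiens) for inhibition, read by sulforhodamine B assay, with a stated time of 48 h, tested at 50 uM; on this read-out higher numbers stand for more inhibition of growth at the one concentration tested and lower numbers for less inhibition of growth:
- compound 1 `COc1ccc(/C=C/C(=O)/C=C/c2ccc(OCc3cn(CCCCOc4cc(=O)oc5ccccc45)nn3)c(OC)c2)cc1OC`: 53%
- compound 2 `COc1cc(/C=C/C(=O)/C=C/c2ccco2)ccc1OCc1cn(CCCCOc2cc(=O)oc3ccccc23)nn1`: 43%
- compound 3 `COc1cc(/C=C/C(=O)/C=C/c2cc(OC)c(OC)c(OC)c2)ccc1OCc1cn(CCCCOc2cc(=O)oc3ccccc23)nn1`: 60%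

Compound 3 gives 60% in this assay. The numbers show a number 7 percentage points higher from compound 1 to compound 3 (within the scatter), so that pair cannot be ordered, and they show a number 17 percentage points higher from compound 2 to compound 3 (beyond the scatter).

The next compound is compound 4 `COc1ccc(/C=C/C(=O)/C=C/c2ccc(OCc3cn(CCCCOc4cc(=O)oc5ccccc45)nn3)c(OC)c2)cc1`, with 4-methoxyphenyl in place of 3,4,5-trimethoxyphenyl on a double-bonded chain carbon bound to a double-bonded chain carbon. Among the measured compounds shown here, no measured compound carries 4-methoxyphenyl. The nearest guide is the methoxy change, which gave a number 7 percentage points higher from compound 1 to compound 3 (within the scatter). The wider replacement of the aryl group by furan-2-yl gave a number 10 percentage points lower from compound 1 to compound 2 (within the scatter), and the change from furan-2-yl to 3,4,5-trimethoxyphenyl gave a number 17 percentage points higher from compound 2 to compound 3 (beyond the scatter). Together these steps suggest a small fall rather than a large one, and it may not clear the scatter. The expected change is a number 9 percentage points lower from compound 3 to compound 4 (within the scatter). For compound 4 the estimated value is 51%, with an expected range from 40% to 62%.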

Compound 4, percent growth inhibition at one concentration: 49%
For compound 4 the middle estimate is 2 percentage points above the measured one, within the range that was stated.
By their numbers in this assay, from the lowest: compounds 2, 4, 1 and 3 (each within the scatter of the next, the first and the last beyond it).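

In this assay, replacing 3,4,5-trimethoxyphenyl with 4-methoxyphenyl on a double-bonded chain carbon bound to a double-bonded chain carbon gave a number 11 percentage points lower from compound 3 to compound 4 (beyond the scatter), the first sign that a phenyl group with methoxy groups can differ from 3,4,5-trimethoxyphenyl at this position. Neighbouring steps do not separate as clearly: hydrogen in place of methoxy on an aromatic carbon gave a number 4 percentage points lower from compound 1 to compound 4 (within the scatter), and 4-methoxyphenyl in place of furan-2-yl gave a number 6 percentage points higher from compound 2 to compound 4 (within the scatter), so neither pair can be ordered, and the loss shows only across the larger change in methoxy groups. Nothing available explains this difference.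

The compounds shown leave open whether a hydroxy or dimethylamino group in place of methoxy on this phenyl ring would match 3,4,5-trimethoxyphenyl. They also leave open how a longer chain in the linker of the shared core would affect growth inhibition.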